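4-Methyl-1H-imidazol-1-yl in place of trifluoromethyl

The compounds below may be only part of what the source reports. "The series", "measured", "known", "first", "only" and "open" are said of these compounds alone.

In a functional assay on K562 cells (Homo sapiens) for inhibition, read by MTT assay, with a stated time of 72 h (on this read-out lower numbers stand for stronger inhibition of growth and higher numbers for weaker inhibition of growth), compound 1 `Nc1n[nH]c2cccc(C#Cc3cccc(C(=O)Nc4cccc(C(F)(F)F)c4)c3)c12` gives 3470 nM, and compound 2 `Nc1n[nH]c2cccc(C#Cc3cccc(C(=O)Nc4cc(C(F)(F)F)cc(C(F)(F)F)c4)c3)c12` gives 520 nM, the lower of the two numbers. Compound 3 `Cc1cn(-c2cc(NC(=O)c3cccc(C#Cc4cccc5[nH]nc(N)c45)c3)cc(C(F)(F)F)c2)cn1` differs from compound 2 in one place: 4-methyl-1H-imidazol-1-yl in place of trifluoromethyl on an aromatic carbon. Going by the values given here, only one measured step bears on this change. Adding a trifluoromethyl group on an aromatic carbon gave a 6.7-fold lower number from compound 1 to compound 2 (0.82 log units; beyond the scatter), a modest step beyond the scatter. Among the compounds with values here, no measured compound carries a ring at this place, so the expectation is uncertain. A modest further drop is expected, a 2.6-fold lower number from compound 2 to compound 3 (0.41 log units; beyond the scatter). Compound 3 is estimated at 200 nM, with an expected range of 40 nM to 1000 nM.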

Compound 3, concentration for 50% growth inhibition: 150 nM
Compound 3: the middle estimate sits 1.3-fold (0.12 log units) above what was measured; measured number inside the range.
By their numbers in this assay, from the lowest: compound 3; then compound 2; then compound 1.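

In this assay this position is not limited to trifluoromethyl: 4-methyl-1H-imidazol-1-yl, a five-membered aromatic ring, gives a 3.5-fold lower number from compound 2 to compound 3 (0.54 log units; beyond the scatter) and so still lowers the number. Measured against hydrogen at the same place, the ring gives a 23-fold lower number from compound 1 to compound 3 (1.36 log units; beyond the scatter) and is a large step. Nothing measured here explains why the number falls. Whether the methyl on the ring matters remains open, since only the methylated imidazole is shown. So does the question of how a plain imidazole or an amine such as morpholine would fare at this place.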